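The source may hold more compounds than are shown below. What is called first, only, known or untested is meant among the compounds shown, and "the series" means these compounds.

Three compounds that share one core were tested in an assay on Sf9 cells for inhibition of inhibitor of nuclear factor kappa-B kinase subunit epsilon (Homo sapiens), read by ADP-Glo, with a stated time of 60 min; a higher number here means a weaker inhibitor, a lower number a stronger inhibitor. Compound 1 `CCCC(=O)n1nc(C)c(-c2ccc(Cl)c(Cl)c2)c1N` carries a propyl group on the carbonyl carbon. In this assay compound 1 reaches only the limit of the assay, > 100000 nM. Compound 2 `Cc1nn(C(=O)C2CC2)c(N)c1-c1ccc(Cl)c(Cl)c1` has cyclopropyl in place of propyl. In this assay compound 2 likewise gives only the limit, > 100000 nM. Compound 3 `Cc1nn(C(=O)C2CCCCC2)c(N)c1-c1ccc(Cl)c(Cl)c1` has cyclohexyl on the same carbonyl carbon. In this assay compound 3 also stops at the limit, > 100000 nM. Compound 3 thus stands level with the other two: the limit of > 100000 nM in this assay, at which 3 of the 3 values shown sit. The steps a step that the two limits leave unreadable from compound 1 to compound 2, a step that the two limits leave unreadable from compound 1 to compound 3 and a step that the two limits leave unreadable from compound 2 to compound 3 are accordingly of unreadable size. Compound 4 `Cc1nn(C(=O)c2ccncc2)c(N)c1-c1ccc(Cl)c(Cl)c1` is not yet measured; it differs from compound 3 by pyridin-4-yl in place of cyclohexyl on a carbonyl carbon. Among the compounds with values here, no measured step yet involves an aromatic group on this carbonyl carbon, and every change made so far has left the read-out at the limit. Compound 4 is therefore expected to remain at or near the limit, estimated at 150000 nM with a range from 30000 nM to 800000 nM. The expected step is a step that the limit leaves unreadable from compound 3 to compound 4, not beyond the scatter.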

Compound 4, half-maximal inhibitory concentration: > 100000 nM
Compound 4 was reported as a limit; the forecaster's own chance of this, stated with the estimate: 85%; the middle value does not contradict the limit.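

Compound 4 gives only a limit in this assay, > 100000 nM. Its steps to compound 1, compound 2 and compound 3 therefore cannot be read: the limit of > 100000 nM in this assay, at which 4 of the 4 values shown sit.

The compounds shown leave open whether any group on this carbonyl carbon gives a measurable value in this assay.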